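Chloro to methyl on two cores: cytotoxicity notes

A few compounds are considered here, and "the series" means these few. Any claim that something is new, unique, unknown or untested is made for them only; others in the source may bear on it.

The series is read in an ADME assay on Vero cells (Chlorocebus sabaeus) for cytotoxicity, read by MTT assay, with a stated time of 72 h; a higher number here means a weaker inhibitor, a lower number a stronger inhibitor. Compound 1 `COc1ccc2c(c1)[n+]([O-])c(C#N)c(-c1ccc(Cl)cc1)[n+]2[O-]` gives 1 ug/mL. Compound 2 `COc1ccc2c(c1)[n+]([O-])c(C#N)c(-c1ccc(C)cc1)[n+]2[O-]` gives 3.8 ug/mL. The change between the two is methyl in place of chloro on an aromatic carbon, and the step it made is a 3.8-fold higher number from compound 1 to compound 2 (0.58 log units; beyond the scatter). Among the measured compounds shown here, compound 3 `COC(=O)c1ccc(-c2c(C#N)[n+]([O-])c3cc(Cl)ccc3[n+]2[O-])cc1` gives 20.9 ug/mL, the highest number of the three measured so far; the difference between its core and the core of compound 1 is not broken down here. Compound 4 `COC(=O)c1ccc(-c2c(C#N)[n+]([O-])c3cc(C)ccc3[n+]2[O-])cc1` is not yet measured and differs from compound 3 by methyl in place of chloro on an aromatic carbon. This is the same kind of change as in the pair above, but not the same: in compound 2 the methyl sits on a ring of carbon only, para to a large group, while in compound 4 it sits on a ring that is part of a fused or bridged system of two rings, meta to a fused ring and para to a fused ring. Resting on the single step of a 3.8-fold higher number from compound 1 to compound 2 (0.58 log units; beyond the scatter) and on compound 3 at 20.9 ug/mL, a modest rise is expected, about a 2.2-fold higher number from compound 3 to compound 4 (0.33 log units; beyond the scatter). Compound 4 is therefore estimated at 45 ug/mL, between 15 ug/mL and 150 ug/mL.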

Compound 4, half-maximal inhibitory concentration: 3.2 ug/mL
Beside the measured number, compound 4's estimate is 14-fold (1.15 log units) above it, outside the stated range (below it).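

In this assay, methyl in place of chloro gives a 6.5-fold lower number from compound 3 to compound 4 (0.81 log units; beyond the scatter), so the step read on the first core does not carry to the second, in direction or in size: the same change on two cores in this assay, a 3.8-fold higher number (0.58 log units; beyond the scatter) from compound 1 to compound 2 and a 6.5-fold lower number (0.81 log units; beyond the scatter) from compound 3 to compound 4, 25-fold (1.39 log units) apart, beyond the scatter of two such steps

For these two pairs, the outcome of this change cannot be taken from one core to the other, and an estimate built on such a transfer has no support in this series. This does not show which difference is responsible, as the two cores differ in more than one place and the change itself sits on a ring of carbon only in one pair and on a ring of the fused system in the other, and two pairs give no general rule.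

On these data alone, it remains open whether the two placements would behave alike on one shared core. Also open, as far as these compounds go, is how an amine or a carboxylic acid at the same aromatic carbon would read in this assay on either core.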